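Lengthening the fluorinated chain of compound 3

This account rests on a few compounds, and the source may have more. Where it says the series, first, only, none or still open, it means among the compounds named here.

Measured in a toxicity assay on HT-29 cells (Homo sapiens) for cytotoxicity; on this read-out higher numbers stand for lower toxicity in this test and lower numbers for higher toxicity in this test:
- Compound 1 `CC(C)Cn1nc(C(=O)N[C@H]2COc3ccccc3N(C)C2=S)nc1Cc1ccccc1`: > 100000 nM, a limit
- Compound 2 `CN1C(=S)[C@@H](NC(=O)c2nc(Cc3ccccc3)n(CCCF)n2)COc2ccccc21`: > 100000 nM, a limit
- Compound 3 `CN1C(=S)[C@@H](NC(=O)c2nc(Cc3ccccc3)n(CCC(F)(F)F)n2)COc2ccccc21`: > 100000 nM, a limit

In this assay compound 3 stands only at a limit, > 100000 nM, and no number is known for it. The picture across the series is the same: the limit of > 100000 nM in this assay, at which 3 of the 3 values shown sit.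

Compound 4 `CN1C(=S)[C@@H](NC(=O)c2nc(Cc3ccccc3)n(CCCC(F)(F)F)n2)COc2ccccc21` differs from compound 3 at one place. It has 2,2,2-trifluoroethyl in place of trifluoromethyl on a saturated chain carbon, two bonds along the chain from an aromatic nitrogen. Cut one bond further out, this is 3,3,3-trifluoropropyl to 4,4,4-trifluorobutyl.

The closest measured change is a step that the two limits leave unreadable from compound 2 to compound 3, made at that same chain carbon. The other two, a step that the two limits leave unreadable from compound 1 to compound 2 and a step that the two limits leave unreadable from compound 1 to compound 3, alter the same substituent on the aromatic nitrogen. None of the three has a readable size, so they supply no size or direction to carry over.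

No step beyond the usual scatter is therefore expected, and the assay will probably report only a limit again. The expected change is a number no higher from compound 3 to compound 4 (the limit leaves the size open). Compound 4 is estimated at 100000 nM, with an expected range from 30000 nM to 200000 nM.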

Compound 4, half-maximal cytotoxic concentration: > 100000 nM
Compound 4 ended at the assay's limit (the forecaster's own chance of this, stated with the estimate: 85%); the middle value sits exactly at the limit.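

In this assay compound 4 gives > 100000 nM, which is a limit and not a number. No step from compound 1, compound 2 or compound 3 to compound 4 can be read, and the series stays at one mark: the limit of > 100000 nM in this assay, at which 4 of the 4 values shown sit.

The compounds shown leave open where any of their true values lies and whether the changes on the chain alter them at all.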